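From Dimethoxyphenyl to Acetylphenyl on a Shared Core

A few compounds are considered here, and "the series" means these few. Any claim that something is new, unique, unknown or untested is made for them only; others in the source may bear on it.

Of the compounds shown here, three sharing one core have been measured in an ADME assay on WI-38 cells (Homo sapiens) for cytotoxicity, read by MTT assay, with a stated time of 72 h; a higher number here means a weaker inhibitor, a lower number a stronger inhibitor. Compound 1 `O=C(CCc1cccc2c1B(O)OC2)Nc1cccc(Br)c1` carries a bromo group and gives 20000 nM. Compound 2 `O=C(CCc1cccc2c1B(O)OC2)Nc1cccc(-c2cccc(Cl)c2)c1` carries a 3-chlorophenyl group at that place and gives 58000 nM. Compound 3 `COc1cc(OC)cc(-c2cccc(NC(=O)CCc3cccc4c3B(O)OC4)c2)c1` carries a 3,5-dimethoxyphenyl group and gives 1700 nM, the lowest number of the three.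

Compound 4 `CC(=O)c1cccc(-c2cccc(NC(=O)CCc3cccc4c3B(O)OC4)c2)c1` has 3-acetylphenyl in place of 3,5-dimethoxyphenyl on an aromatic carbon.

The closest measured precedent is the swap of one such group for another, a 34-fold lower number from compound 2 to compound 3 (1.53 log units; beyond the scatter), which was large. The steps from the bromo group point in opposite directions: a 2.9-fold higher number from compound 1 to compound 2 (0.46 log units; beyond the scatter) was modest, while a 12-fold lower number from compound 1 to compound 3 (1.07 log units; beyond the scatter) was large. Only the 3,5-dimethoxyphenyl group has brought the number down, so compound 3 at 1700 nM looks like the low outlier rather than the norm. By name, the 3-acetylphenyl group reads closer to the 3-chlorophenyl group, though an acetyl is not a chloro, so only part of the way back towards compound 2 is expected. The expected change is a 5.9-fold higher number from compound 3 to compound 4 (0.77 log units; beyond the scatter), a sizeable rise in this assay. For compound 4 the estimated value is 10000 nM, with an expected range of 2800 nM to 40000 nM.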

Compound 4, half-maximal inhibitory concentration: 2200 nM
Compound 4: middle estimate off by 4.5-fold (0.66 log units), on the high side; measured number below the stated range.
By their numbers in this assay, from the lowest: compounds 3 and 4 (each within the scatter of the next); then compound 1; then compound 2.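

In this assay the low number of compound 3 no longer stands alone: a 1.3-fold higher number from compound 3 to compound 4 (0.11 log units; within the scatter) places two differently substituted phenyl groups together at the low end, so the 3,5-dimethoxyphenyl group is not the only one that gets there. The position also turns out to respond to what the added phenyl ring carries, not just to that ring being present, since a 26-fold lower number from compound 2 to compound 4 (1.42 log units; beyond the scatter) comes from putting acetyl in place of chloro on that ring, a single change that accounts for nearly all of the gap between these two compounds. Measured against the bromo compound, a 9.1-fold lower number from compound 1 to compound 4 (0.96 log units; beyond the scatter) runs in the same direction as the step to compound 3, which leaves compound 2 as the one compound among these with a phenyl group in place of bromo that goes the other way.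

From the compounds shown here alone, whether a single methoxy, an amine or a carboxylic acid on that ring would join compound 3 and compound 4 or fall back towards compound 2 remains open. Nothing available here accounts for the large difference between the chloro and acetyl compounds.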